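From ureido to 4-methylpiperazin-1-yl in a cytotoxic series

The compounds below may be only part of what the source reports. "The series", "measured", "known", "first", "only" and "open" are said of these compounds alone.

Compound 1 `N#Cc1c(Cl)nc(SCc2nc3ccccc3[nH]2)nc1-c1ccccc1` gives 11.3 nM
Compound 2 `N#Cc1c(NC(N)=S)nc(SCc2nc3ccccc3[nH]2)nc1-c1ccccc1` gives 11.9 nM
Compound 3 `N#Cc1c(NC(N)=O)nc(SCc2nc3ccccc3[nH]2)nc1-c1ccccc1` gives 4.54 nM

In a functional assay on K562 cells (Homo sapiens) for cytotoxicity, read by MTT assay, with a stated time of 3 days (on this read-out higher numbers stand for weaker inhibition and lower numbers for stronger inhibition), compound 3 stands lowest of the three measured compounds, at 4.54 nM on this read-out. Compound 4 `CN1CCN(c2nc(SCc3nc4ccccc4[nH]3)nc(-c3ccccc3)c2C#N)CC1` has not yet been measured. It carries 4-methylpiperazin-1-yl in place of ureido on an aromatic carbon, ortho to a cyano group: 4-methylpiperazin-1-yl in place of ureido on an aromatic carbon is the whole difference. Within the data shown here, three measured steps concern this place. Two lead into ureido, namely a 2.5-fold lower number from compound 1 to compound 3 (0.40 log units; beyond the scatter) and a 2.6-fold lower number from compound 2 to compound 3 (0.42 log units; beyond the scatter) as modest gains, while a 1.1-fold higher number from compound 1 to compound 2 (0.02 log units; within the scatter) shows no change between the two groups without ureido. Compound 4 gives up ureido, so a modest move back toward a higher number is expected, of about the size of those two steps. Among the measured compounds shown here, no measured compound has a ring at this place, which leaves the estimate uncertain. The expected step is a 2.2-fold higher number from compound 3 to compound 4 (0.34 log units; beyond the scatter) in this assay as a rough guide. For compound 4 the estimated value is 10 nM with an expected range from 3 nM to 35 nM at this stage.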

Compound 4, half-maximal inhibitory concentration: 2.4 nM
For compound 4 the middle estimate is 4.2-fold (0.62 log units) above the measured one; measured number outside the range, below it.
By their numbers in this assay, from the lowest: compounds 4 and 3 (each within the scatter of the next); then compounds 1 and 2 (each within the scatter of the next).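

In this assay, the position ortho to a cyano group accepts a ring as well as an open chain, since the change from ureido to 4-methylpiperazin-1-yl gives a 1.9-fold lower number from compound 3 to compound 4 (0.28 log units; within the scatter). The low numbers therefore do not depend on ureido: compound 4 also stands clear of the compounds with the other two groups, with a 4.7-fold lower number from compound 1 to compound 4 (0.67 log units; beyond the scatter) and a 5.0-fold lower number from compound 2 to compound 4 (0.70 log units; beyond the scatter). Nothing available explains why these two quite different groups give such similar numbers.

On these data alone, it remains open whether the ring as a whole, its second nitrogen or its methyl carries this result; morpholine, or piperazine with a free ring nitrogen, would separate these. Also open, as far as these compounds go, is whether the result holds with a group other than phenyl on the shared core, such as a pyridyl ring.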